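Two analogues of a shared core, and a third to estimate

The compounds below may be only part of what the source reports. "The series", "measured", "known", "first", "only" and "open" are said of these compounds alone.

Measured so far:
compound 1 `FC(F)(F)c1ccccc1NCn1nc(-c2ccc3c(c2)OCCO3)oc1=S` gives 9220 nM
compound 2 `S=c1oc(-c2ccc3c(c2)OCCO3)nn1CNc1ccc(Br)cc1` gives 14700 nM

Both values come from a functional assay, with a stated time of 6 min; a higher number here means a weaker inhibitor, a lower number a stronger inhibitor. Compound 2 has the higher of the two numbers, yet its gap to compound 1 is within the usual scatter of repeated measurements, so the two compounds cannot be ranked against each other on this evidence.

Compound 3 `O=[N+]([O-])c1ccccc1NCn1nc(-c2ccc3c(c2)OCCO3)oc1=S` has not been measured. It differs from compound 2 in one place: 2-nitrophenyl in place of 4-bromophenyl on an amine nitrogen. Among the compounds with values here, no measured pair here shows what such a change does, so there is no step to lean on, and the two measured values give no guidance either way.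

The expectation is therefore that compound 3 stays near compound 2, with any step from a 1.3-fold lower number from compound 2 to compound 3 (0.13 log units; within the scatter) not beyond the scatter. The estimated value for compound 3 in this assay is 11000 nM, within a range from 3500 nM to 35000 nM.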

Compound 3, half-maximal inhibitory concentration: 10900 nM
Compound 3: middle estimate off by 1.0-fold (0.00 log units), on the high side; measured number inside the range.
By their numbers in this assay, from the lowest: compounds 1, 3 and 2 (each within the scatter of the next).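

In this assay, 2-nitrophenyl in place of 4-bromophenyl on the amine nitrogen gives a 1.3-fold lower number from compound 2 to compound 3 (0.13 log units; within the scatter), so this change of both group and printed ring position produces no readable shift, even though the entering group carries hydrogen-bond acceptors that the leaving group lacks. Nitro in place of trifluoromethyl gives a 1.2-fold higher number from compound 1 to compound 3 (0.07 log units; within the scatter), so this exchange on an aromatic carbon also stays within the scatter, and compounds 1, 2 and 3 cannot be ranked against one another. No measurement bears on what lies behind these small steps.

As far as these compounds go, all three compounds carry a substituted phenyl ring on the amine nitrogen, so it remains open whether an unsubstituted phenyl, a phenyl bearing a carboxylic acid or an amine, or a saturated alkyl chain would move the number beyond the scatter. From the compounds shown here alone, it is also open whether 2-bromophenyl would differ from 4-bromophenyl.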